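Chain extension at the amine across a thioether-bearing core

The source may hold more compounds than are shown below. What is called first, only, known or untested is meant among the compounds shown, and "the series" means these compounds.

Measured compounds:
compound 1 `CCCCNc1nc(SCC)nc2ncccc12`, 9200 nM
compound 2 `CCCCCNc1nc(SCC)nc2ncccc12`, 1300 nM
compound 3 `CCCCCCNc1nc(SC(C)C)nc2ncccc12`, 4500 nM

In a functional assay on MDA-MB-231 cells (Homo sapiens) for cytotoxicity, read by neutral red uptake, with a stated time of 72 h (a lower number here means a stronger inhibitor, a higher number a weaker inhibitor), compound 1 gives 9200 nM and compound 2 gives 1300 nM. The change between them is methyl in place of hydrogen on a saturated chain carbon, four bonds along the chain from a nitrogen on an aromatic ring, and it gave a 7.1-fold lower number from compound 1 to compound 2 (0.85 log units; beyond the scatter). Compound 3 carries a different thioether and a longer amine chain; in this assay compound 3 gives 4500 nM. The difference between the core of compound 1 and the core of compound 3 is not broken down here.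

Compound 4 `CCCCCCCNc1nc(SC(C)C)nc2ncccc12` is not yet measured. It differs from compound 3 by methyl in place of hydrogen on a saturated chain carbon, six bonds along the chain from a nitrogen on an aromatic ring. Among the compounds with values here, this is the same kind of change as the one from compound 1 to compound 2, not the same change: there the entering methyl sat four bonds along the chain from the nitrogen on the aromatic ring, here it sits six bonds along the chain.

Within the data shown here, only one such step is known, and it was made on a different core. For compound 4 the expected step in this assay is a 2.3-fold lower number from compound 3 to compound 4 (0.35 log units; beyond the scatter), smaller than the earlier one because a 7.1-fold lower number from compound 1 to compound 2 (0.85 log units; beyond the scatter) was measured on a shorter chain and the carry-over to compound 3, which stands at 4500 nM, is uncertain. Compound 4 is therefore estimated at 2000 nM, with a likely range from 700 nM to 6000 nM.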

Compound 4, half-maximal inhibitory concentration: 7000 nM
Compound 4: middle estimate off by 3.5-fold (0.54 log units), on the low side; the measured number lies above the stated range.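

In this assay the added methyl gives a 1.6-fold higher number from compound 3 to compound 4 (0.19 log units; within the scatter), so on the core of compound 3 this change yields no difference beyond the scatter, whereas the same kind of change on the core of compound 1 gave a 7.1-fold lower number from compound 1 to compound 2 (0.85 log units; beyond the scatter). The gain seen on the core of compound 1 therefore did not carry over to the core of compound 3, and the two steps clearly disagree: the same change on two cores in this assay, a 7.1-fold lower number (0.85 log units; beyond the scatter) from compound 1 to compound 2 and a 1.6-fold higher number (0.19 log units; within the scatter) from compound 3 to compound 4, 11-fold (1.04 log units) apart, beyond the scatter of two such steps. This does not show what separates the two steps, since they differ both in the thioether on the core and in where the methyl enters, four bonds along the chain from the nitrogen on the aromatic ring in one step and six bonds along it in the other, and a single pair on each side cannot tell these apart.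

Open, as far as these compounds go, is whether a methyl entering four bonds along the chain would give a similar gain on the isopropyl thioether, and whether one entering six bonds along the chain would leave the number on the ethyl thioether unchanged. Also open, from the compounds shown here alone, is how a longer chain, or a chain carrying a carboxylic acid or a hydroxyl group, would read in this assay.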